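Ethylcarbamoyl for pyridin-4-yl on the aminopyridine sulfonamide core

The source may report more compounds than this note shows. Statements on the series, on what has been measured and on what is new or still open speak of the compounds shown alone.

Compound 2 `COc1ccc(Cl)cc1S(=O)(=O)Nc1cncc(-c2ccncc2)c1` gives 73 nM in an assay on isolated protein for inhibition of alkaline phosphatase, tissue-nonspecific isozyme (Homo sapiens); a lower number here means a stronger inhibitor, a higher number a weaker inhibitor. Compound 1 `COc1ccc(OC)c(S(=O)(=O)Nc2cncc(-c3ccncc3)c2)c1` gives 73 nM in this assay, and the step of no change at the digits printed from compound 1 to compound 2 (within the scatter) shows the two level with each other; together they hold the highest numbers of the three measured. Compound 3 `COc1ccc(C#N)cc1S(=O)(=O)Nc1cnc2ccccc2c1`, built on a different core, gives 38 nM in this assay, and its gap to compound 2 stays within the scatter.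

Compound 4 `CCNC(=O)c1cncc(NS(=O)(=O)c2cc(Cl)ccc2OC)c1` carries the change ethylcarbamoyl in place of pyridin-4-yl on an aromatic carbon: ethylcarbamoyl in place of pyridin-4-yl, on an aromatic carbon of the core, two atoms from the ring nitrogen. Going by the values given here, no measured step touches this position; the only step on record, from compound 1 to compound 2, alters the other aryl ring and leaves the number unchanged, so it gives no guidance on swapping an aromatic ring for an amide chain here. Among the compounds with values here, the expectation for this assay therefore rests on no direct precedent and is set with a wide range, allowing for some loss.

Compound 4 is expected to reach about 150 nM in this assay, between 40 nM and 600 nM. The step expected from compound 2 to compound 4 is a 2.1-fold higher number from compound 2 to compound 4 (0.31 log units; beyond the scatter).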

Compound 4, half-maximal inhibitory concentration: 193 nM
Compound 4: middle estimate off by 1.3-fold (0.11 log units), on the low side, within the range that was stated.
By their numbers in this assay, from the lowest: compounds 3, 1 and 2 (each within the scatter of the next); then compound 4.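

Going by these compounds alone, the step of a 2.6-fold higher number from compound 2 to compound 4 (0.42 log units; beyond the scatter) in this assay is the first reading at this position, and it shows that the pyridin-4-yl ring is not essential: with an ethylcarbamoyl chain and no ring there, compound 4 still gives 193 nM in this series. Within the data shown here, this position therefore moves the number, which the one earlier step, made on the other aryl ring, did not do. Nothing on record accounts for the shift. 

Going by these compounds, a single pair cannot separate the loss of the ring from the entry of the amide, so the separate roles of the ethyl chain and the amide hydrogen stay open. Also open, on these data alone, is how a shorter or longer chain on the amide, a carboxylic acid or a simple amine would read at this position.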